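Swapping 4-bromophenyl for 2,2,2-trifluoroethoxy on compound 3

The source may hold more compounds than are shown below. What is called first, only, known or untested is meant among the compounds shown, and "the series" means these compounds.

Compound 1, `CN(C)c1cc2[nH]c(C3CCCCC3)nc2cc1NC(=O)c1ccc(Br)cc1`, in an ADME assay on Vero cells (Chlorocebus sabaeus) for cytotoxicity, read by resazurin assay, with a stated time of 3 days (on this read-out lower numbers stand for stronger inhibition and higher numbers for weaker inhibition), gives only the limit > 100 ug/mL. Compound 2, `CCN(CC)c1cc2[nH]c(C3CCCCC3)nc2cc1NC(=O)c1ccc(N(C)C)cc1`, in this assay gives "not determined" (no result reported). Compound 3, `O=C(Nc1cc2nc(C3CCCCC3)[nH]c2cc1N1CCCC1)c1ccc(Br)cc1`, in this assay gives only the limit > 100 ug/mL.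

Compound 3 therefore stands at a limit rather than at a number, and the same holds for compound 1, while compound 2 brings no result at all; this is summed up by the limit of > 100 ug/mL in this assay, at which 2 of the 3 values shown sit. For the measured compounds named here, the one measured step, a step that the two limits leave unreadable from compound 1 to compound 3, cannot be sized, since both ends are limits.

Compound 4, `O=C(Nc1cc2nc(C3CCCCC3)[nH]c2cc1N1CCCC1)OCC(F)(F)F`, differs from compound 3 in 2,2,2-trifluoroethoxy in place of 4-bromophenyl on a carbonyl carbon. Going by the values given here, no measured step touches this part of the molecule: the step from compound 1 to compound 3 changes the amine on the aromatic carbon, not the group on the carbonyl carbon, and its size is unreadable anyway. The expectation for compound 4 thus rests on compound 3 alone, whose > 100 ug/mL is a limit. In this assay compound 4 is expected to give 110 ug/mL, with a range from 40 ug/mL to 300 ug/mL. The step that this estimate means, a step that the limit leaves unreadable from compound 3 to compound 4, is expected to be none beyond the scatter, and a further limit is the most likely outcome.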

Compound 4, half-maximal inhibitory concentration: > 100 ug/mL
Compound 4 ended at the assay's limit; the forecaster's own chance of this, stated with the estimate: 70%; the middle value does not contradict the limit.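

In this assay compound 3 and compound 4 both sit at a limit rather than at a number, so no step can be read for 2,2,2-trifluoroethoxy in place of 4-bromophenyl. The compounds shown leave open whether either change alters the read-out at all, as none of them gives a single number: the limit of > 100 ug/mL in this assay, at which 3 of the 4 values shown sit.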